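From ethoxy to 3-(methylsulfonyl)propoxy on a shared core

This account rests on a few compounds, and the source may have more. Where it says the series, first, only, none or still open, it means among the compounds named here.

Within the data shown here, three compounds went into a physicochemical assay for lipophilicity, using the shake flask method, in phosphate buffer, measured as octanol-water partition, with a stated time of 24 h, at pH 7.4, tested at 100 uM (a higher number here means a more lipophilic compound, a lower number a more polar compound), and only one returned a number. Compound 3 (`CCOc1cc(C)c(-c2cccc(COc3ccc(OCC(=O)O)c(F)c3)c2)c(C)c1`) gives 3.48 and so stands alone, with nothing to rank it against. For compound 1 (`Cc1cc(OCc2cccc(-c3c(C)cc(OCCCS(C)(=O)=O)cc3C)c2)ccc1N(CC(=O)O)C(=O)c1ccccc1`) the entry reads "not determined" (no result reported) and for compound 2 (`Cc1cc(OC(C)C)cc(C)c1-c1cccc(COc2ccc(OCC(=O)O)c(F)c2)c1`) the entry reads "not determined" (no result reported) in the same way.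

Compound 4 (`Cc1cc(OCCCS(C)(=O)=O)cc(C)c1-c1cccc(COc2ccc(OCC(=O)O)c(F)c2)c1`) differs from compound 3 in one place ((methylsulfonyl)methyl in place of hydrogen on a saturated chain carbon, two bonds along the chain from an oxygen on an aromatic ring): (methylsulfonyl)methyl stands in place of hydrogen on a saturated chain carbon, two bonds along the chain from an oxygen on an aromatic ring, which turns ethoxy into 3-(methylsulfonyl)propoxy. Compound 1 carries that same chain but offers no number for comparison.

Among the measured compounds shown here, no measured pair shows a step of this kind, so the expectation rests on the structural change alone: a fall in this assay beyond the usual scatter. For the measured compounds named here, the estimated size is a number 1.18 log units lower from compound 3 to compound 4 (beyond the scatter) and no measurement yet supports it. In this assay compound 4 is expected at 2.3 with an estimated range from 1.7 to 2.9 around it.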

Compound 4, distribution coefficient: 1.81
Compound 4: middle estimate off by 0.49 log units, on the high side; measured number inside the range.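

In this assay, among these compounds, the change from ethoxy to 3-(methylsulfonyl)propoxy gives the first step that can be read at this position, a number 1.67 log units lower from compound 3 to compound 4 (beyond the scatter). Among the compounds shown here, the earlier compounds offered only a single number, so this step is the first sign that the read-out responds to a change on this saturated chain carbon, two bonds along the chain from an oxygen on an aromatic ring. It is one pair on one core, however, and supports no wider pattern.

As far as these compounds go, it stays open whether a hydroxyl, an amine or a longer chain ending in the same sulfone would move the number as far, and whether the step holds on the core of compound 1, which carries the same 3-(methylsulfonyl)propoxy chain. Nothing in the data shown accounts for the size of the step.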